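Methylsulfanyl in Place of Carbamoyl: An Expected Dose

A few compounds are considered here, and "the series" means these few. Any claim that something is new, unique, unknown or untested is made for them only; others in the source may bear on it.

Measured so far in a functional assay on the whole organism for activation, with Mus musculus as the target; on this read-out higher numbers stand for an effect only at larger amounts of compound and lower numbers for an effect already at smaller amounts:
compound 1, `CC(=O)C1(c2cc(F)cc(OCc3ccc(-n4ccnc4C)cc3)c2)CCOCC1`, 12 mg/kg
compound 2, `Cc1nccn1-c1ccc(COc2cc(F)cc(C3(C(N)=O)CCOCC3)c2)cc1`, 4.9 mg/kg
compound 3, `CCOC1(c2cc(F)cc(OCc3ccc(-n4ccnc4C)cc3)c2)CCOCC1`, 5 mg/kg

Compound 2 has the lowest of the three numbers, though compound 3 sits within the scatter of it, so the two cannot be ordered; only compound 1 stands apart, as the steps of a 2.4-fold lower number from compound 1 to compound 2 (0.39 log units; beyond the scatter) and a 2.4-fold lower number from compound 1 to compound 3 (0.38 log units; beyond the scatter) show. Compound 4, `CSC1(c2cc(F)cc(OCc3ccc(-n4ccnc4C)cc3)c2)CCOCC1`, is not yet measured. It differs from compound 2 by methylsulfanyl in place of carbamoyl on a saturated ring carbon. The step that bears on this is a 1.0-fold higher number from compound 2 to compound 3 (0.01 log units; within the scatter), where the carbamoyl also gave way to a group without a carbonyl and the number did not move beyond the scatter. The step of a 1.1-fold higher number from compound 2 to compound 4 (0.05 log units; within the scatter) is therefore expected to stay within the scatter. Compound 4 is estimated at 5.5 mg/kg, with a range from 2.5 mg/kg to 12 mg/kg.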

Compound 4, dose for half-maximal effect: 5 mg/kg
For compound 4 the middle estimate is 1.1-fold (0.04 log units) above the measured one; the measured number falls inside the stated range.
By their numbers in this assay, from the lowest: compounds 2, 3 and 4 (each within the scatter of the next); then compound 1.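

In this assay, methylsulfanyl joins carbamoyl and ethoxy as a group on this saturated ring carbon that cannot be told apart from the others (a 1.0-fold higher number from compound 2 to compound 4 (0.01 log units; within the scatter); no change at the digits printed from compound 3 to compound 4 (within the scatter)), so the hydrogen-bond donor of the carbamoyl is not needed to hold the number within the scatter. Acetyl alone stands apart (a 2.4-fold lower number from compound 1 to compound 4 (0.38 log units; beyond the scatter)), and nothing available gives a reason for this. Going by these compounds, whether an amine, a carboxylic acid or a longer chain on this carbon would stay with the lower three numbers or fall with compound 1 remains open.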